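A few compounds are considered here, and "the series" means these few. Any claim that something is new, unique, unknown or untested is made for them only; others in the source may bear on it.

Going by the values given here, compound 1 `CO[C@@](C)(CCCC(C)C)c1ccc(CO)cc1O` holds the only number in this set: in a functional assay on cells (Neutrophil, Homo sapiens) for inhibition, read by spectrophotometry, with a stated time of 5 min (a lower number here means a stronger inhibitor, a higher number a weaker inhibitor), compound 1 gives 13800 nM, so it stands as the sole reference point. Compound 2 `C=C(CCCC(C)C)c1ccc(CO)cc1O` is the other entry, and in this assay compound 2 is recorded as "not determined" (no result reported), which gives no number to compare. Compound 3 `CC(C)CCC[C@](C)(O)c1ccc(CO)cc1O` is the compound to be measured. It differs from compound 1 in one place: hydrogen in place of methyl on an oxygen on a saturated carbon. Among the compounds with values here, no step between two measured compounds is in hand, so the set itself does not calibrate what a methoxy-to-hydroxy exchange does here. The expected step from compound 1 to compound 3 in this assay is a 1.4-fold lower number from compound 1 to compound 3 (0.14 log units; within the scatter), a small move, if any, toward a stronger inhibitor and not clearly beyond the usual scatter. Compound 3 is therefore estimated at 10000 nM, with a range of 3000 nM to 40000 nM.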

Compound 3, half-maximal inhibitory concentration: 5230 nM
Beside the measured number, compound 3's estimate is 1.9-fold (0.28 log units) above it; measured number inside the range.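

Going by these compounds alone, exchanging methoxy for hydroxy on the saturated carbon gives a 2.6-fold lower number from compound 1 to compound 3 (0.42 log units; beyond the scatter) in this assay and supplies the first calibrated step, a modest one that lies beyond the scatter. The methyl on this oxygen is therefore not required for inhibition in this pair, and the free hydroxy form, compound 3, is the stronger inhibitor of the two. No supporting measurement bears on the origin of this step, so it stands as an observation only.

Within the data shown here, compound 2 has no number, so no step involving it can be read. A single exchange on this oxygen leaves open whether an ethoxy group, an acetate ester or an amine in place of the hydroxy would hold or shift the number.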